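Acetyl to cyclohexylcarbonyl in the series

The compounds below may be only part of what the source reports. "The series", "measured", "known", "first", "only" and "open" are said of these compounds alone.

Of the compounds shown here, three have numbers so far in a functional assay on THP-1 cells (Homo sapiens) for inhibition, with a stated time of 4 h; a lower number here means a stronger inhibitor, a higher number a weaker inhibitor. Compound 1 `O=C(CN1CCCN(C(=O)c2ccccc2)C[C@H](NC(=O)c2cccc(C(F)(F)F)c2)C1=O)N[C@H]1CC(=O)OC1O` gives 1020 nM, compound 2 `O=CN1CCCN(CC(=O)N[C@H]2CC(=O)OC2O)C(=O)[C@@H](NC(=O)c2ccc3ccccc3c2)C1` gives 219 nM and compound 3 `CC(=O)N1CCCN(CC(=O)N[C@H]2CC(=O)OC2O)C(=O)[C@@H](NC(=O)c2ccc3ccccc3c2)C1` gives 216 nM. Compound 3 therefore sits level with compound 2, and both lie clearly under compound 1. Compound 1 differs from compound 3 in more than one place, so that gap cannot be tied to a single change.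

The next compound is compound 4 `O=C(CN1CCCN(C(=O)C2CCCCC2)C[C@H](NC(=O)c2ccc3ccccc3c2)C1=O)N[C@H]1CC(=O)OC1O`, with cyclohexyl in place of methyl on a carbonyl carbon, the acetyl of compound 3 becoming cyclohexylcarbonyl: cyclohexyl in place of methyl on a carbonyl carbon. Going by the values given here, only one measured step bears on this position, a 1.0-fold lower number from compound 2 to compound 3 (0.01 log units; within the scatter), which is methyl in place of hydrogen on the same carbonyl carbon and stays within the scatter. Among the compounds with values here, that step is flat, but it covers a far smaller change, and no larger group has yet been measured here. The evidence therefore points to no shift beyond the scatter in this assay, with little support in either direction and a wide margin needed. The expected step is a 1.1-fold lower number from compound 3 to compound 4 (0.03 log units; within the scatter). For compound 4 the estimated value is 200 nM, with an expected range of 80 nM to 500 nM.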

Compound 4, half-maximal inhibitory concentration: 577 nM
Estimate against measurement, compound 4: 2.9-fold (0.46 log units) below, and the stated range ends below it.
By their numbers in this assay, from the lowest: compounds 3 and 2 (each within the scatter of the next); then compounds 4 and 1 (each within the scatter of the next).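

Cyclohexyl on this carbonyl carbon gives a 2.7-fold higher number from compound 3 to compound 4 (0.43 log units; beyond the scatter), and with hydrogen as the starting point the result is similar, a 2.6-fold higher number from compound 2 to compound 4 (0.42 log units; beyond the scatter). In this assay the position therefore does respond to the group it carries, a response that the exchange of hydrogen for methyl gave no sign of, although the rise in the number with cyclohexyl is only modest. No measurement at hand accounts for this rise.

The two end points leave open where between methyl and cyclohexyl the rise sets in, and whether an isopropyl or cyclopropyl group on the same carbonyl carbon would read like methyl or like cyclohexyl. Also open, from the compounds shown here alone, is how an amine-bearing group such as piperidin-4-yl would behave here, while compound 1, with phenyl on this carbonyl carbon, differs from compound 4 in a second place and so cannot show what an aromatic ring does at this position alone.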